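Open-Chain Amine in Place of Pyrrolidine

The source may report more compounds than this note shows. Statements on the series, on what has been measured and on what is new or still open speak of the compounds shown alone.

compound 1 `CCC(COC)Nc1nc(C)nc2c1nnn2-c1c(C)cc(C)cc1C`: 59.4 nM
compound 2 `Cc1nc(N2CCCC2)c2nnn(-c3ccc(C(C)C)cc3Br)c2n1`: 194 nM

In an in vitro assay on 293-EBNA cells for binding affinity to corticotropin-releasing factor receptor 1 (Homo sapiens) (a lower number here means a stronger inhibitor, a higher number a weaker inhibitor), compound 1 gives 59.4 nM and compound 2 gives 194 nM, so compound 2 has the higher of the two numbers, and its gap to compound 1 lies beyond the scatter. Compound 3 `CCN(c1nc(C)nc2c1nnn2-c1ccc(C(C)C)cc1Br)C(COC)COC` differs from compound 2 in one place: a group of 10 heavy atoms (7 carbon, 1 nitrogen, 2 oxygen; no ring) in place of a group of 5 heavy atoms (4 carbon, 1 nitrogen; one five-membered non-aromatic ring with 1 hetero atom), on an aromatic carbon. Among the measured compounds shown here, no measured pair isolates this change, because compound 1 differs from compound 2 in the aryl group as well. Since compound 1 also carries an open-chain amine and gives 59.4 nM, a modest move toward a lower number is expected, a 2.8-fold lower number from compound 2 to compound 3 (0.44 log units; beyond the scatter). Compound 3 is expected to give 70 nM, between 18 nM and 280 nM.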

Compound 3, inhibition constant: 123 nM
Beside the measured number, compound 3's estimate is 1.8-fold (0.24 log units) below it; low and high end bracket the measured number.
By their numbers in this assay, from the lowest: compound 1; then compounds 3 and 2 (each within the scatter of the next).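

Replacing pyrrolidin-1-yl with the larger open-chain amine, which has no ring and carries 3 hydrogen-bond acceptors, gives a 1.6-fold lower number from compound 2 to compound 3 (0.20 log units; within the scatter) in this assay. This position on the shared core therefore accepts a much larger group with no ring, and the numbers for the two compounds cannot be told apart. Nothing available explains this result.

From the compounds shown here alone, it remains open whether a morpholine ring or a plain diethylamino group at this position would also stay within the scatter of compound 2.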